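The source may report more compounds than this note shows. Statements on the series, on what has been measured and on what is new or still open speak of the compounds shown alone.

In an in vivo ADME assay on the whole organism (plasma) for pharmacokinetics, with Canis familiaris (Canis lupus familiaris) as the target, at a dose of 1 mg/kg by the oral route (a higher number here means more compound in the circulation at the dose given, a lower number less compound in the circulation), compound 1 (`CCCC[C@H]1CN(c2cccc(C)c2C)C(=O)CN1Cc1cncn1Cc1ccc(C#N)cc1`) reaches 140 nM and compound 3 (`CCCC[C@H]1CN(c2cccc(C)c2C)CC(=O)N1Cc1cncn1Cc1ccc(C#N)cc1`) reaches 960 nM while compound 2 (`N#Cc1ccc(Cn2cncc2CN2CCN(c3cccc(Cl)c3)C(=O)C2=O)cc1`) reaches 3110 nM at the same dose. Compound 2 thus stands highest of the three, beyond the scatter of both others, with compound 3 nearest and compound 1 furthest. Compound 4 (`Cc1cccc(N2CCN(Cc3cncn3Cc3ccc(C#N)cc3)C(=O)C2=O)c1C`) has not yet been measured. It keeps the core of compound 2 and takes 2,3-dimethylphenyl in place of 3-chlorophenyl on an amide-type nitrogen in a ring. Within the data shown here, no measured pair differs at this place alone, so the data give no direct size for the change. Compound 1 at 140 nM and compound 3 at 960 nM also carry the 2,3-dimethylphenyl group and lie lower, but their cores differ from that of compound 2 and they are only a loose guide. A modest fall is therefore expected in this assay with an estimated step of a 1.7-fold lower number from compound 2 to compound 4 (0.24 log units; within the scatter) and a step of that size would stay within the scatter. For compound 4 the estimated maximal plasma concentration is 1800 nM with an expected range from 650 nM to 4500 nM at that dose.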

Compound 4, maximal plasma concentration in the Canis familiaris assay: 2290 nM
Estimate against measurement, compound 4: 1.3-fold (0.10 log units) below; low and high end bracket the measured number.
By their numbers in the Canis familiaris assay, from the lowest: compound 1; then compound 3; then compounds 4 and 2 (each within the scatter of the next).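

In the Canis familiaris assay, compound 2 gives 3110 nM and compound 4 gives 2290 nM. In the Canis familiaris assay, 2,3-dimethylphenyl in place of 3-chlorophenyl on the amide-type nitrogen gives a 1.4-fold lower number from compound 2 to compound 4 (0.13 log units; within the scatter). This is the only step shown that isolates this position, and it shows that, on the core of compound 2, the chlorine-bearing ring can give way to the dimethyl-substituted ring without a difference that rises beyond the scatter. In a physicochemical assay for lipophilicity (on this read-out lower numbers stand for lower lipophilicity and higher numbers for higher lipophilicity), compound 2 gives 1.24 and compound 4 gives 1.11. In the physicochemical assay the same exchange gives a number 0.13 log units lower from compound 2 to compound 4 (within the scatter), so neither read-out separates the two compounds, and nothing further is available that would explain this result.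

The compounds shown leave open how far this position tolerates groups of another kind, such as a phenyl ring bearing an amine or a carboxylic acid, or a cyclohexyl group in place of the aromatic ring. With a single step at this position, they also leave open whether the same exchange would give a similarly small step on the cores of compound 1 and compound 3, or at other doses and in other species.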